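The source may hold more compounds than are shown below. What is called first, only, known or untested is meant among the compounds shown, and "the series" means these compounds.

In an ADME assay on MT4 cells (Homo sapiens) for cytotoxicity, with a stated time of 5 days (a lower number here means that less compound is tolerated, a higher number that more compound is tolerated), compound 1 `CC(C)(C)C#Cc1cc(N(C(=O)[C@H]2CC[C@H](C)CC2)[C@H]2CC[C@H](OC3CCOCC3)CC2)c(C(=O)O)s1` gives > 20000 nM, which is a limit and not a number. Compound 2 `CC(C)(C)C#Cc1cc(N(C(=O)[C@H]2CC[C@H](C)CC2)[C@H]2CC[C@H](Oc3ccc(=O)[nH]n3)CC2)c(C(=O)O)s1` gives > 20000 nM, also a limit. Compound 2 therefore stands at the limit of > 20000 nM in this assay, at which 2 of the 2 values shown sit. Compound 3 `C[C@H]1CC[C@H](C(=O)N(c2cc(C#CC3(C(F)(F)F)CC3)sc2C(=O)O)[C@H]2CC[C@H](Oc3ccc(=O)[nH]n3)CC2)CC1` carries 1-(trifluoromethyl)cyclopropyl in place of tert-butyl on a triple-bonded carbon. Among the compounds with values here, the only measured step, a step that the two limits leave unreadable from compound 1 to compound 2, changes a group on an oxygen on a saturated carbon, so it says nothing about this place, and no change beyond the usual scatter is expected in this assay. The expected step is a number no higher from compound 2 to compound 3 (the limit leaves the size open). Compound 3 is estimated at 20000 nM, with an expected range from 9000 nM to 40000 nM.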

Compound 3, half-maximal cytotoxic concentration: > 20000 nM
Compound 3: no number, only a limit (the forecaster's own chance of this, stated with the estimate: 75%); the middle value lies on the limit itself.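

Within the data shown here, compound 2 and compound 3 each give only a limit and not a number, so no step between them can be read. The compounds shown leave open whether either change alters the result in this assay.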